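The source may hold more compounds than are shown below. What is called first, only, known or untested is meant among the compounds shown, and "the series" means these compounds.

Compound 1 `CC(C)=CC(=O)Nc1c(C(O)(C(F)(F)F)C(F)(F)F)ccc2ccccc12`: in a functional assay (Sus scrofa) with sulfonylurea receptors; K-ATP channels (Homo sapiens) as the target (a higher number here means that more compound is needed for the effect, a lower number that less compound is needed), compound 1 gives 550 nM.
Compound 2 `O=C(Nc1c(C(O)(C(F)(F)F)C(F)(F)F)ccc2ccccc12)c1ccco1`: in this assay compound 2 gives 182 nM.

Within the data shown here, compound 2 holds the lower of the two numbers in this assay; the only measured step is a 3.0-fold lower number from compound 1 to compound 2 (0.48 log units; beyond the scatter). Compound 3 `O=C(Nc1c(C(O)(C(F)(F)F)C(F)(F)F)ccc2ccccc12)c1cccnc1` differs from compound 2 by pyridin-3-yl in place of furan-2-yl on a carbonyl carbon. Among the measured compounds shown here, no measured step exchanges one aromatic ring for another, and the single step known, which brings furan-2-yl in for a non-aromatic group, does not cover this change. The estimate is therefore a 1.4-fold higher number from compound 2 to compound 3 (0.14 log units; within the scatter), nothing beyond the scatter. Compound 3 is expected to give 250 nM, within a range from 90 nM to 700 nM.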

Compound 3, half-maximal effective concentration: 617 nM
For compound 3 the middle estimate is 2.5-fold (0.39 log units) below the measured one, within the range that was stated.
By their numbers in this assay, from the lowest: compound 2; then compounds 1 and 3 (each within the scatter of the next).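

In this assay, swapping one aromatic ring for another on this carbonyl carbon carries a real change (a 3.4-fold higher number from compound 2 to compound 3 (0.53 log units; beyond the scatter)), so what furan-2-yl gave does not extend to pyridin-3-yl. Pyridin-3-yl and 2-methylprop-1-en-1-yl cannot be told apart here (a 1.1-fold higher number from compound 1 to compound 3 (0.05 log units; within the scatter)), so having an aromatic ring at this place is not enough on its own to lower the number. Nothing at hand accounts for the difference between the two rings. Open, going by these compounds, is where phenyl or thiophen-2-yl would fall on the same carbonyl carbon, and whether a saturated amine there would keep the number of compound 2.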